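Piperidine ester to methylpiperazine: cytotoxicity in the nitrobenzamides

The compounds below may be only part of what the source reports. "The series", "measured", "known", "first", "only" and "open" are said of these compounds alone.

Compound 2 `COC(=O)C1CCN(c2cc(Cl)c(C(=O)Nc3cc(-c4nc5ccccc5s4)ccc3OC)cc2[N+](=O)[O-])CC1` is the reference point of this note. In an ADME assay on BJ cells (Homo sapiens) for cytotoxicity, with a stated time of 72 h (on this read-out lower numbers stand for an effect already at smaller amounts and higher numbers for an effect only at larger amounts of compound), compound 2 gives > 25000 nM, which is a limit of the assay and not a number. Compound 1 `O=C(Nc1cccc(-c2nc3ccccc3o2)c1)c1cc([N+](=O)[O-])ccc1Cl` is likewise at a limit: in this assay compound 1 gives > 25000 nM. Compound 3 `COC(=O)C1CCN(c2cc(Cl)c(C(=O)Nc3cc(-c4nc5ccccc5s4)ccc3C)cc2[N+](=O)[O-])CC1` too stands at a limit, since in this assay compound 3 gives > 25000 nM. Going by the values given here, the single step between neighbouring compounds, a step that the two limits leave unreadable from compound 2 to compound 3, is thus not readable in size. The whole of the series is summed up by the limit of > 25000 nM in this assay, at which 3 of the 3 values shown sit.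

Among the compounds with values here, compound 4 `COc1ccc(-c2nc3ccccc3s2)cc1NC(=O)c1cc([N+](=O)[O-])c(N2CCN(C)CC2)cc1Cl` differs from compound 2 in one place. 4-methylpiperazin-1-yl in place of 4-(methoxycarbonyl)piperidin-1-yl on an aromatic carbon No measured step covers this exchange, and the one step that is known gives no number. With every measured compound at the limit, no step beyond the scatter is expected, so the estimated step is a number no higher from compound 2 to compound 4 (the limit leaves the size open). Compound 4 is therefore estimated at 25000 nM, with a range from 10000 nM to 60000 nM, and most probably it will again be reported only as a limit.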

Compound 4, half-maximal effective concentration in the BJ assay: > 25000 nM
Compound 4: only a limit was reported; the forecaster's own chance of this, stated with the estimate: 80%; the middle value sits exactly at the limit.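

Going by these compounds alone, in the BJ assay, compound 2 and compound 4 both stand at a limit, so no step between them can be read. In a physicochemical assay for solubility, read by spectrophotometry, in phosphate buffer, measured as kinetic solubility, with a stated time of 18 h, at pH 7.4 (on this read-out lower numbers stand for lower solubility and higher numbers for higher solubility), compound 2 gives 170 nM and compound 4 gives 500 nM. The compounds shown leave open which change, if any, would give a number rather than a limit in the BJ assay.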